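A few compounds are considered here, and "the series" means these few. Any claim that something is new, unique, unknown or untested is made for them only; others in the source may bear on it.

In a functional assay on cells (Melanoma cell, Homo sapiens) for cytotoxicity, read by sulforhodamine B assay, with a stated time of 48 h (a lower number here means a stronger inhibitor of growth, a higher number a weaker inhibitor of growth), compound 1 `COc1ccc(C2=NN(C3=NC(=O)/C(=C4\C(=O)Nc5ccccc54)S3)C(c3ccc(OC)cc3)C2)cc1` gives 100000 nM. Compound 2 `COc1ccc(C2CC(c3ccc4ccccc4c3)=NN2C2=NC(=O)/C(=C3\C(=O)Nc4ccccc43)S2)cc1` differs from it by naphthalen-2-yl in place of 4-methoxyphenyl on a carbon with a double bond to nitrogen, and in this assay compound 2 gives 27000 nM, a step of a 3.7-fold lower number from compound 1 to compound 2 (0.57 log units; beyond the scatter). Compound 3 `COc1ccc(C2=NN(C3=NC(=O)/C(=C4\C(=O)Nc5ccccc54)S3)C(c3ccc(Cl)cc3)C2)cc1` carries a smaller change, (chloro in place of methoxy on an aromatic carbon), and in this assay compound 3 gives 100000 nM, so that no change at the digits printed from compound 1 to compound 3 (within the scatter).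

Compound 4 `O=C1N=C(N2N=C(c3ccc4ccccc4c3)CC2c2ccc(Cl)cc2)S/C1=C1/C(=O)Nc2ccccc21` is not yet measured. It stands to compound 3 as compound 2 stands to compound 1, through (naphthalen-2-yl in place of 4-methoxyphenyl on a carbon with a double bond to nitrogen). The surroundings are not identical in every word: in compound 3 the ring atom two ring bonds away bears a 4-chlorophenyl group, whereas in compound 1 it bears a 4-methoxyphenyl group, so this is the same kind of change rather than the same change. Because compound 3 sits level with compound 1 in this assay, no change at the digits printed from compound 1 to compound 3 (within the scatter), a similar outcome is expected here: the step is estimated as a 3.7-fold lower number from compound 3 to compound 4 (0.57 log units; beyond the scatter), set beside a 3.7-fold lower number from compound 1 to compound 2 (0.57 log units; beyond the scatter). On that basis compound 4 is expected to give about 27000 nM in this assay, plausibly between 10000 nM and 100000 nM.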

Compound 4, concentration for total growth inhibition: 24700 nM
Estimate against measurement, compound 4: 1.1-fold (0.04 log units) above; measured number inside the range.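

With naphthalen-2-yl in place of 4-methoxyphenyl, this assay shows a 4.0-fold lower number from compound 3 to compound 4 (0.61 log units; beyond the scatter), and the step carries over from one core to the other without a difference: the same change on two cores in this assay, a 3.7-fold lower number (0.57 log units; beyond the scatter) from compound 1 to compound 2 and a 4.0-fold lower number (0.61 log units; beyond the scatter) from compound 3 to compound 4, 1.1-fold (0.04 log units) apart, within the scatter of two such steps. Chloro in place of methoxy on an aromatic carbon gives a 1.1-fold lower number from compound 2 to compound 4 (0.04 log units; within the scatter), and this change too reads the same whether 4-methoxyphenyl or naphthalen-2-yl is present: the same change on two cores in this assay, no change at the digits printed (within the scatter) from compound 1 to compound 3 and a 1.1-fold lower number (0.04 log units; within the scatter) from compound 2 to compound 4, 1.1-fold (0.04 log units) apart, within the scatter of two such steps. Together the two comparisons show that, across these four compounds, each change has the same outcome in both settings, but they rest on one pair per core and do not show that the naphthalen-2-yl step would persist on any core beyond these two or explain why it occurs.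

The compounds shown leave open whether an amine or a carboxylic acid in place of chloro on the aromatic ring would keep the naphthalen-2-yl step unchanged. They also leave open whether a longer chain in place of naphthalen-2-yl would lower the number further in this assay.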